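Compound 2 gains a (tert-butyl)carbonyl on oxygen

The compounds below may be only part of what the source reports. "The series", "measured", "known", "first", "only" and "open" are said of these compounds alone.

Compound 1 `O=C1NC(=O)c2c1c1c(O)cccc1c1[nH]c3ccccc3c21`: 46400 nM
Compound 2 `O=C1NC(=O)c2c1c1c(O)ccc(O)c1c1[nH]c3ccccc3c21`: 5600 nM
Compound 3 `CC(C)(C)C(=O)Oc1ccc(O)c2c3c(c4c5ccccc5[nH]c4c12)C(=O)NC3=O`: not yet measured

In a functional assay on HT-29 cells (Homo sapiens) for antiproliferative activity, with a stated time of 4 h (on this read-out higher numbers stand for weaker inhibition and lower numbers for stronger inhibition), compound 2 holds the lower of the two numbers. Among the measured compounds shown here, the only measured step is an 8.3-fold lower number from compound 1 to compound 2 (0.92 log units; beyond the scatter), for hydroxy in place of hydrogen on an aromatic carbon. Compound 3 differs from compound 2 by (tert-butyl)carbonyl in place of hydrogen on an oxygen on an aromatic ring, which reads as hydroxy to ((tert-butyl)carbonyl)oxy. The change falls on the hydroxy that this step added, so compound 3 no longer has that hydroxy free. For the measured compounds named here, no measured compound shows this change itself. The gain of an 8.3-fold lower number from compound 1 to compound 2 (0.92 log units; beyond the scatter) is therefore expected to be partly lost, with the number moving back toward compound 1 at 46400 nM. The expected step is a 2.7-fold higher number from compound 2 to compound 3 (0.43 log units; beyond the scatter). For compound 3 the estimate is 15000 nM, with an expected range from 4000 nM to 60000 nM.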

Compound 3, half-maximal inhibitory concentration: 7280 nM
Compound 3: middle estimate off by 2.1-fold (0.31 log units), on the high side; low and high end bracket the measured number.
By their numbers in this assay, from the lowest: compounds 2 and 3 (each within the scatter of the next); then compound 1.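

In this assay, placing (tert-butyl)carbonyl on the oxygen of the added hydroxy leaves the number within the scatter (a 1.3-fold higher number from compound 2 to compound 3 (0.11 log units; within the scatter)), so among these compounds a free hydroxy at this position is not needed to hold the number. The larger ((tert-butyl)carbonyl)oxy group, in place of hydrogen on the aromatic carbon, also keeps a gain beyond the scatter (a 6.4-fold lower number from compound 1 to compound 3 (0.80 log units; beyond the scatter)), so this position accepts more than a hydroxy. Nothing available on these compounds explains this result.

The compounds shown leave open whether compound 3 acts in the cells as it stands or after losing its (tert-butyl)carbonyl. They also leave open whether a methoxy, an amine or a carboxylic acid at this position would give a similar number.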